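A few compounds are considered here, and "the series" means these few. Any claim that something is new, unique, unknown or untested is made for them only; others in the source may bear on it.

Measured so far in a functional assay on P388 cells (Mus musculus) for cytotoxicity, read by MTT assay, with a stated time of 72 h; a higher number here means a weaker inhibitor, a lower number a stronger inhibitor:
compound 1, `CCOc1cccc(/C=N/c2c(C)n(C)n(-c3ccccc3)c2=O)c1`, gives 295000000 nM
compound 2, `Cc1c(/N=C/c2cccc(O)c2)c(=O)n(-c2ccccc2)n1C`, gives 437000000 nM

Going by the values given here, of the two numbers in this assay, the one for compound 2 is the larger figure, but compound 1 lies within the usual scatter of it, so the two cannot be told apart. Among the compounds with values here, the only measured step, a 1.5-fold higher number from compound 1 to compound 2 (0.17 log units; within the scatter), came from putting hydrogen in place of ethyl on an oxygen on an aromatic ring and did not move the number beyond the scatter. Compound 3, `COc1ccccc1/C=N/c1c(C)n(C)n(-c2ccccc2)c1=O`, has not been measured. It differs from compound 2 by 2-methoxyphenyl in place of 3-hydroxyphenyl on a carbon with a double bond to nitrogen. Within the data shown here, the step from compound 1 to compound 2 is the only comparison that bears on this change; it also concerned the aromatic ring that carries the oxygen and was small, which gives no reason to expect a large effect here. The step of a 1.2-fold lower number from compound 2 to compound 3 (0.10 log units; within the scatter) is therefore expected to be none beyond the scatter. Compound 3 is estimated at 350000000 nM in this assay, with a range from 120000000 nM to 1000000000 nM.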

Compound 3, half-maximal inhibitory concentration: 229000000 nM
For compound 3 the middle estimate is 1.5-fold (0.18 log units) above the measured one; low and high end bracket the measured number.
By their numbers in this assay, from the lowest: compounds 3, 1 and 2 (each within the scatter of the next).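

In this assay the change to 2-methoxyphenyl gave a 1.9-fold lower number from compound 2 to compound 3 (0.28 log units; within the scatter) even though it replaces the whole aromatic group on the carbon with a double bond to nitrogen. The earlier step altered only what sat on the oxygen, whereas this one also changes the number in the group's name and goes from 1 hydrogen-bond donor to 0, and still no difference can be read between the two compounds. No measurement is available here that would explain this result.

On these data alone, what remains open is whether any group at this place can move the number beyond the scatter, for example an amine, a carboxylic acid, or a longer chain on the oxygen. The compounds shown also leave open whether changes elsewhere on the shared core would matter more than changes on this aromatic ring.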